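The source may hold more compounds than are shown below. What is called first, only, known or untested is meant among the compounds shown, and "the series" means these compounds.

Measured so far:
Compound 1, `Oc1ccccc1-c1cc(-c2cccc(OC(F)(F)F)c2)cc(-c2ccccc2O)n1`, gives 7470 nM in a functional assay on DU-145 cells (Homo sapiens) for inhibition; a lower number here means a stronger inhibitor, a higher number a weaker inhibitor.
Compound 2, `Oc1cccc(-c2cc(-c3cccc(OC(F)(F)F)c3)cc(-c3ccccc3O)n2)c1`, gives > 50000 nM in this assay; this is a limit of the assay, not a number.

Compound 2 thus stands at the weak end of what is known, at the limit of > 50000 nM in this assay, at which 1 of the 2 values shown sits. Within the data shown here, the one measured step, an at least 6.6-fold higher number from compound 1 to compound 2 (0.82 log units; beyond the scatter), moved the hydroxyl from the 2-position to the 3-position and lost activity. Compound 3, `Oc1ccc(-c2cc(-c3cccc(OC(F)(F)F)c3)cc(-c3ccccc3O)n2)cc1`, carries the change (4-hydroxyphenyl in place of 3-hydroxyphenyl on an aromatic carbon). Among the measured compounds shown here, no measured step covers a 3-hydroxyphenyl to 4-hydroxyphenyl exchange, so the direction is open; given that compound 2 already sits at the limit, the expected step that the limit leaves unreadable from compound 2 to compound 3 is small. Compound 3 is estimated at 60000 nM (range 15000 nM to 250000 nM).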

Compound 3, half-maximal inhibitory concentration: > 50000 nM
Compound 3: only a limit was reported (the forecaster's own chance of this, stated with the estimate: 70%); the middle value is on the limit's open side.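

In this assay, the 4-hydroxyphenyl group also falls short of the 2-hydroxyphenyl group at this position (an at least 6.6-fold higher number from compound 1 to compound 3 (0.82 log units; beyond the scatter)), so the loss is not specific to the 3-hydroxyphenyl group. Compound 2 and compound 3 both give only a limit of the assay, not a number: the limit of > 50000 nM in this assay, at which 2 of the 3 values shown sit. The step between them therefore cannot be read, and the 3-hydroxyphenyl and 4-hydroxyphenyl groups cannot be ranked.

Open, as far as these compounds go, is whether the hydroxyl itself matters here, which a 2-methoxyphenyl or 2-aminophenyl group at this position would test. Also open, from the compounds shown here alone, is how much activity an unsubstituted phenyl group would keep.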